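The source may hold more compounds than are shown below. What is called first, only, known or untested is meant among the compounds shown, and "the series" means these compounds.

Measured so far in an ADME assay on microsomes from liver (Mus musculus) for metabolic stability, using NADPH, with a stated time of 10 min; a higher number here means that more of the compound is left, a lower number that less of the compound is left:
compound 1 `NC/C=C/CN(C[C@H]1Cc2ncccc2CN1)[C@H]1CCCc2cccnc21`: 37%
compound 2 `NC(=O)NC/C=C/CN(C[C@H]1Cc2ncccc2CN1)[C@H]1CCCc2cccnc21`: 19%
compound 3 `CN(CCCCN(C[C@H]1Cc2ncccc2CN1)[C@H]1CCCc2cccnc21)C1CCOCC1`: 51%

Compound 1 stands second highest of the three in this assay; the nearest step is a number 14 percentage points higher from compound 1 to compound 3 (beyond the scatter) and the furthest is a number 18 percentage points lower from compound 1 to compound 2 (beyond the scatter). Compound 4 `c1cnc2c(c1)CN[C@@H](CN(CCCC1CCNCC1)[C@H]1CCCc3cccnc31)C2` is not yet measured. It differs from compound 1 in that (2-(piperidin-4-yl)ethyl in place of 3-aminoprop-1-en-1-yl on a saturated chain carbon bound to an amine nitrogen). The step that bears on this is a number 14 percentage points higher from compound 1 to compound 3 (beyond the scatter), where the same leaving group gave way to a larger group holding a six-membered non-aromatic ring with one hetero atom; a number 32 percentage points higher from compound 2 to compound 3 (beyond the scatter) points the same way. The entering group here is smaller than that in compound 3 and keeps a hydrogen-bond donor. For compound 4 a smaller rise is therefore expected, a number 8 percentage points higher from compound 1 to compound 4 (within the scatter). Compound 4 is estimated at 45%, within 30% to 60%.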

Compound 4, percent of the compound remaining: 69%
The estimate for compound 4 lay 24 percentage points below the measured number; measured number above the stated range.
By their numbers in this assay, from the lowest: compound 2; then compound 1; then compound 3; then compound 4.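

In this assay, a group ending in a six-membered non-aromatic ring with one hetero atom need not be large at this position: 2-(piperidin-4-yl)ethyl gives a number 32 percentage points higher from compound 1 to compound 4 (beyond the scatter) and a number 50 percentage points higher from compound 2 to compound 4 (beyond the scatter). The smaller ring-bearing group also stands above the larger one, with a number 18 percentage points higher from compound 3 to compound 4 (beyond the scatter), so a bigger group does not track with more compound left across these compounds. No measurement at hand explains these steps.

On these data alone, compound 4 differs from compound 1 in both ring and double bond, so their separate contributions stay open. A 4-aminobutyl group at this position would separate them.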